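This account rests on a few compounds, and the source may have more. Where it says the series, first, only, none or still open, it means among the compounds named here.

In a functional assay on MDA-MB-231 cells (Homo sapiens) for cytotoxicity, read by MTT assay, with a stated time of 96 h (on this read-out higher numbers stand for weaker inhibition and lower numbers for stronger inhibition), compound 1 (`CC[C@H](NC)C(=O)N[C@@H]1C(=O)N2[C@@H](CC[C@@H]1CN)CC[C@H]2C(=O)NC(c1ccccc1)c1ccccc1`) gives 542 nM and compound 2 (`CC[C@H](N)C(=O)N[C@@H]1C(=O)N2[C@@H](CC[C@@H]1CCO)CC[C@H]2C(=O)NC(c1ccccc1)c1ccccc1`) gives 1800 nM as the higher of the two numbers, a gap beyond the usual scatter. Compound 3 (`CCNCC[C@H]1CC[C@H]2CC[C@@H](C(=O)NC(c3ccccc3)c3ccccc3)N2C(=O)[C@H]1NC(=O)[C@@H](N)CC`) carries ethylamino in place of hydroxy on a saturated chain carbon, two bonds along the chain from a saturated ring carbon. Going by the values given here, no measured pair isolates this change, so a modest step towards lower numbers is expected in this assay and it may stay within the scatter. The estimated step (a 2.0-fold lower number from compound 2 to compound 3 (0.30 log units; within the scatter)) is small. Compound 3 is expected to give 900 nM in a range from 300 nM to 2700 nM when measured.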

Compound 3, half-maximal inhibitory concentration: 8000 nM
For compound 3 the middle estimate is 8.9-fold (0.95 log units) below the measured one; the whole stated range lies below it.
By their numbers in this assay, from the lowest: compound 1; then compound 2; then compound 3.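

In this assay, ethylamino in place of hydroxy on a saturated chain carbon, two bonds along the chain from a saturated ring carbon, gives a 4.4-fold higher number from compound 2 to compound 3 (0.65 log units; beyond the scatter). This first single-place step shows that the position is sensitive to this change, with the 2-(ethylamino)ethyl chain going with weaker inhibition than the 2-hydroxyethyl chain. Nothing given here explains the step. On these data alone, whether the ethyl group or the nitrogen itself goes with the weaker inhibition stays open, and a plain 2-aminoethyl chain would separate the two. As far as these compounds go, how a carboxylic acid or a longer chain would read at this place also stays open.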